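The source may hold more compounds than are shown below. What is called first, only, known or untested is meant among the compounds shown, and "the series" means these compounds.

Working notes on the series. In an ADME assay on MIA PaCa-2 cells (Homo sapiens) for cytotoxicity, read by MTT assay, with a stated time of 72 h (on this read-out lower numbers stand for stronger inhibition and higher numbers for weaker inhibition), compound 1 (`COc1ccc(C2=C(c3cc(OC)c(OC)c(OC)c3)C(=O)C(OC(C)=O)C2)cc1`) reads < 1 ug/mL, which is a limit of the assay and not a number. Compound 2 (`COc1ccc(C2=C(c3cc(OC)c(OC)c(OC)c3)C(=O)C(O)C2)cc1`) reads < 1 ug/mL, also a limit. Compound 3 (`COc1ccc(C2=C(c3cc(OC)c(OC)c(OC)c3)C(=O)C(O[SiH2]C(C)(C)C)C2)cc1`) reads < 1 ug/mL, again a limit. The whole measured set comes down to the limit of < 1 ug/mL in this assay, at which 3 of the 3 values shown sit.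

Compound 4 (`COc1ccc(C2=C(c3cc(OC)c(OC)c(OC)c3)C(=O)C(OC(C)=O)C2)cc1Cl`) keeps the acetyl of compound 1 and changes the aryl group, 4-methoxyphenyl to 3-chloro-4-methoxyphenyl: chloro in place of hydrogen on an aromatic carbon. The measured steps are a step that the two limits leave unreadable from compound 1 to compound 2, a step that the two limits leave unreadable from compound 1 to compound 3 and a step that the two limits leave unreadable from compound 2 to compound 3. All three concern the group on the oxygen on a saturated carbon, none touches the 4-methoxyphenyl group, and none has a readable size. Within the data shown here, no measured step therefore offers a size or direction for this change. The expected outcome in this assay is a step that the limit leaves unreadable from compound 1 to compound 4, with no step beyond the scatter and no direction estimated. The estimate for compound 4 is 0.5 ug/mL, with an expected range of 0.1 ug/mL to 2 ug/mL.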

Compound 4, half-maximal inhibitory concentration: 24 ug/mL
Estimate against measurement, compound 4: 48-fold (1.68 log units) below; measured number above the stated range.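

In this assay, chloro in place of hydrogen on an aromatic carbon, ortho to a methoxy group, gives an at least 24-fold higher number from compound 1 to compound 4 (1.38 log units; beyond the scatter). Among these compounds, this is the first readable step, and it shows that this assay responds to a change on the 4-methoxyphenyl group, whereas the steps on the oxygen on a saturated carbon cannot be read. The read-out of compound 4 is the only number here that is not a limit, so the size of the step has only a lower bound: the limit of < 1 ug/mL in this assay, at which 3 of the 4 values shown sit.

Going by these compounds, whether fluoro or methyl on the same aromatic carbon would give a step of this kind stays open. On these data alone, it is also open whether the chloro step holds with hydrogen in place of acetyl, as in compound 2.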